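A few compounds are considered here, and "the series" means these few. Any claim that something is new, unique, unknown or untested is made for them only; others in the source may bear on it.

Within this set the shared core of compound 3 `N#Cc1cccc(-n2nnc(-c3ccccn3)n2)c1` carries a cyano group on the carbon-only ring. In a functional assay for antagonist activity at metabotropic glutamate receptor 5 (Homo sapiens) (on this read-out higher numbers stand for weaker inhibition and lower numbers for stronger inhibition), compound 3 gives 73 nM, the highest number among the three measured compounds. Compound 1 `Fc1cc(-n2nnc(-c3ccccn3)n2)cc(-n2ccc3ccncc32)c1` gives 16 nM in this assay, and compound 2 `Fc1cc(Cc2cccnc2)cc(-n2nnc(-c3ccccn3)n2)c1` gives 17 nM; both sit beyond the scatter below compound 3. Among the compounds with values here, the one single-point step recorded, a 1.1-fold higher number from compound 1 to compound 2 (0.03 log units; within the scatter), concerns the group on the fluorinated ring and shows that exchanging one ring-bearing group for another there leaves the number essentially unchanged. Compound 4 `c1ccc(Oc2cccc(-n3nnc(-c4ccccn4)n3)c2)nc1` differs from compound 3 by (pyridin-2-yl)oxy in place of cyano on an aromatic carbon. Within the data shown here, no measured step covers this exact exchange; compounds 1 and 2 differ from compound 3 in more than one place, so their lower numbers can only suggest that a ring-bearing group at this position goes with a lower number. A modest step down is therefore expected, a 2.4-fold lower number from compound 3 to compound 4 (0.39 log units; beyond the scatter), towards the region of compounds 1 and 2, with wide uncertainty. The estimate for compound 4 in this assay is 30 nM, expected to lie between 9 nM and 100 nM.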

Compound 4, half-maximal inhibitory concentration: 2860 nM
Compound 4: the middle estimate sits 95-fold (1.98 log units) below what was measured, outside the stated range (above it).
By their numbers in this assay, from the lowest: compounds 1 and 2 (each within the scatter of the next); then compound 3; then compound 4.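

At this position, on an aromatic carbon of the carbon-only ring, meta to a large group, (pyridin-2-yl)oxy in place of cyano gives a 39-fold higher number from compound 3 to compound 4 (1.59 log units; beyond the scatter) in this assay. A ring-bearing group here therefore does not in itself go with a lower number, and the ring-bearing groups of compounds 1 and 2 give no guide to this exchange. Nothing available bears on the reason for a step of this size.

On these data alone, it remains open whether the step follows from the loss of the nitrile or from the entry of (pyridin-2-yl)oxy, which methoxy, phenoxy or an amine at the same place could begin to separate. Also open, as far as these compounds go, is whether the same exchange on the fluorinated core gives a step of similar size.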